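This account rests on a few compounds, and the source may have more. Where it says the series, first, only, none or still open, it means among the compounds named here.

Two pairs of hydrazone compounds share a pattern. Compound 1, with the structure `CCOC(=O)N1CCC(=NNC(=O)c2ccc(C(F)(F)F)cc2)CC1`, and compound 2, with the structure `CCOC(=O)N1CCC(=NNC(=O)c2ccc([N+](=O)[O-])cc2)CC1`, have the same core and differ only in one substituent: nitro in place of trifluoromethyl on an aromatic carbon. In a functional assay for inhibition, read by spectrophotometry, with a stated time of 120 min (a lower number here means a stronger inhibitor, a higher number a weaker inhibitor), compound 1 gives 49300 nM and compound 2 gives 40200 nM, so the change brings a 1.2-fold lower number from compound 1 to compound 2 (0.09 log units; within the scatter).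

Compound 3, with the structure `O=C(NN=C1CC(c2ccccc2)NC(c2ccccc2)C1)c1ccc(C(F)(F)F)cc1`, carries the same trifluoromethyl group on a different core; the difference between the two cores is not broken down here. In this assay compound 3 gives 55300 nM, which sits close to the numbers for compound 1 and compound 2.

Compound 4, with the structure `O=C(NN=C1CC(c2ccccc2)NC(c2ccccc2)C1)c1ccc([N+](=O)[O-])cc1`, is compound 3 after the same change: nitro in place of trifluoromethyl on an aromatic carbon. Since this change made only a small step on the core of compound 1, a step of about a 1.2-fold lower number from compound 3 to compound 4 (0.09 log units; within the scatter) is expected here, resting on compound 1 and compound 2 because a 1.2-fold lower number from compound 1 to compound 2 (0.09 log units; within the scatter) is within the scatter. Compound 4 is therefore estimated to give 45000 nM in this assay, with a plausible range from 20000 nM to 100000 nM.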

Compound 4, half-maximal inhibitory concentration: 45200 nM
Compound 4: the middle estimate sits 1.0-fold (0.00 log units) below what was measured; low and high end bracket the measured number.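

On the second core, in this assay, replacing trifluoromethyl with nitro gives a 1.2-fold lower number from compound 3 to compound 4 (0.09 log units; within the scatter), so the swap again makes no readable difference. Set beside the earlier step, the change behaves alike on the two cores: the same change on two cores in this assay, a 1.2-fold lower number (0.09 log units; within the scatter) from compound 1 to compound 2 and a 1.2-fold lower number (0.09 log units; within the scatter) from compound 3 to compound 4, 1.0-fold (0.00 log units) apart, within the scatter of two such steps

Going by these compounds alone, this shows only that a swap with no readable effect on the core of compound 1 also has no readable effect on the core of compound 3; it does not show that the two cores would respond alike to a change that moves the number beyond the scatter, and two cores with one pair of groups cannot establish a general rule for the series.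

Going by these compounds, it remains open whether a group of another kind, such as an amine, a carboxylic acid or a longer carbon chain, would give a clear step at this place on the aromatic ring. If such a group did, it would also remain to be seen whether that step carries over from one core to the other at the same size.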